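This account rests on a few compounds, and the source may have more. Where it says the series, first, only, none or still open, it means among the compounds named here.

Series notes, solubility. In a physicochemical assay for solubility, read by HPLC, using the shake flask method, measured as kinetic solubility, with a stated time of 2 h, at pH 7.4 (on this read-out higher numbers stand for higher solubility and lower numbers for lower solubility), compound 1 `Cc1cccc(CNc2cc(C)nc3c(-c4ccccc4)c(C)nn23)n1` returns only a limit, < 5000 nM. Compound 2 `Cc1cc(NCc2ccccn2)n2ncc(-c3ccc(C(F)(F)F)cc3)c2n1` likewise returns only a limit, < 5000 nM. Compound 3 `Cc1cc(NCc2ccccn2)n2ncc(-c3c(C)cccc3C)c2n1` also returns only a limit, < 5000 nM. Within the data shown here, every value so far therefore rests at the limit of < 5000 nM in this assay, at which 3 of the 3 values shown sit, and compound 3 stands among them without any number to set it apart from the others. The next compound, compound 4 `Cc1cc(NCc2ccccn2)n2ncc(-c3cccc(N(C)C)c3)c2n1`, differs from compound 3 by 3-(dimethylamino)phenyl in place of 2,6-dimethylphenyl on an aromatic carbon. Among the measured compounds shown here, no step between measured compounds is available to set a size for this change. A modest gain in this assay is expected, and the step of an at least 1.2-fold higher number from compound 3 to compound 4 (0.07 log units; that floor lies within the scatter) is the estimate carried here. For compound 4 the expected value in this assay is 6000 nM, with a range from 1500 nM to 25000 nM, and a real chance that the read-out again stops at a limit.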

Compound 4, solubility: 94600 nM
Estimate against measurement, compound 4: 16-fold (1.20 log units) below; the measured number lies above the stated range.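

At this position, on an aromatic carbon of the five-membered aromatic ring, the substituent can move the read-out in this assay: 3-(dimethylamino)phenyl in place of 2,6-dimethylphenyl gives an at least 18-fold higher number from compound 3 to compound 4 (1.27 log units; beyond the scatter). Compound 3 gives only a limit, so this step is a floor and not a full size. The earlier compounds offered no number to compare: the limit of < 5000 nM in this assay, at which 3 of the 4 values shown sit.

On these data alone, it remains open whether the step follows from the dimethylamino group entering or from 2,6-dimethylphenyl leaving. A morpholine or a primary amine in place of the dimethylamino group would help separate the two.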